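Replacing the 2-hydroxyphenyl on the saturated ring carbon

The source may report more compounds than this note shows. Statements on the series, on what has been measured and on what is new or still open speak of the compounds shown alone.

Compound 1 `Cc1cc(O)c(C2=NN(c3ccc(S(N)(=O)=O)cc3)C(c3ccccc3O)C2)cc1Cl` is the reference point of the pair so far measured. In a functional assay on COLO 205 cells (Homo sapiens) for antiproliferative activity, with a stated time of 48 h (on this read-out higher numbers stand for weaker inhibition of growth and lower numbers for stronger inhibition of growth), compound 1 gives 1950 nM, the lowest of the two numbers. Compound 2 `Cc1cc(O)c(C2=NN(c3ccc(S(N)(=O)=O)cc3)C(/C=C/c3ccccc3)C2)cc1Cl` carries a 2-phenylethenyl in place of the 2-hydroxyphenyl on the saturated ring carbon; in this assay compound 2 gives 10400 nM, and the step of a 5.3-fold higher number from compound 1 to compound 2 (0.73 log units; beyond the scatter) is the only one recorded at this position.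

Compound 3 `COc1ccc(C2CC(c3cc(Cl)c(C)cc3O)=NN2c2ccc(S(N)(=O)=O)cc2)c(OC)c1OC` is not yet measured. It differs from compound 1 in the same place: 2,3,4-trimethoxyphenyl in place of 2-hydroxyphenyl on a saturated ring carbon. Within the data shown here, the one relevant step, a 5.3-fold higher number from compound 1 to compound 2 (0.73 log units; beyond the scatter), shows that exchanging the 2-hydroxyphenyl at this carbon for another group moved the number upward and beyond the scatter. The entering 2,3,4-trimethoxyphenyl is not the 2-phenylethenyl, so the size is uncertain, but a step in the same direction is expected, of the order of a 3.1-fold higher number from compound 1 to compound 3 (0.49 log units; beyond the scatter). Compound 3 is therefore estimated at 6000 nM in this assay, with a range from 1800 nM to 20000 nM.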

Compound 3, concentration for 50% growth inhibition: 1720 nM
For compound 3 the middle estimate is 3.5-fold (0.54 log units) above the measured one; measured number below the stated range.
By their numbers in this assay, from the lowest: compounds 3 and 1 (each within the scatter of the next); then compound 2.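

In this assay, the 2-hydroxyphenyl on the saturated ring carbon can give way to 2,3,4-trimethoxyphenyl with no change beyond the scatter (a 1.1-fold lower number from compound 1 to compound 3 (0.05 log units; within the scatter)), so the rise seen with compound 2 does not hold for every exchange at this carbon. This holds even though the entering group has 12 heavy atoms against 7 and 0 hydrogen-bond donors against 1, so among these compounds neither the free hydroxyl nor the smaller size of the leaving group is needed to keep the number where compound 1 has it. Compound 2 now stands apart from both aryl-bearing compounds (a 6.0-fold lower number from compound 2 to compound 3 (0.78 log units; beyond the scatter)), and it is the only one of the three with an ethenyl link between this carbon and its ring, although no available evidence explains this separation or the other steps at this position.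

On these data alone, with only these three groups, the contribution of each methoxy group of the 2,3,4-trimethoxyphenyl remains open, as does whether a single methoxy or an unsubstituted phenyl would match compound 1. Also open, as far as these compounds go, is how an amine, a carboxylic acid or a saturated alkyl chain at this carbon would read in this assay.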